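The source may report more compounds than this note shows. Statements on the series, on what has been measured and on what is new or still open speak of the compounds shown alone.

Working notes on the series. In a functional assay on HeLa cells (Homo sapiens) for antiproliferative activity, read by MTT assay, with a stated time of 48 h (on this read-out higher numbers stand for weaker inhibition and lower numbers for stronger inhibition), compound 1 (`COc1ccc(C(=O)c2ccc(OC)c3c2OC(C)(C)C=C3)c(NC(=O)CO)c1`) reads 100 nM and compound 2 (`C=C(c1ccc(OC)cc1NC(=O)CN)c1ccc(OC)c2c1OC(C)(C)C=C2`) reads 120 nM on the same scale. These two numbers lie within the usual scatter of each other, so compound 2 stands level with compound 1 and no order can be drawn between them. Going by the values given here, the two compounds differ in more than one place, so they offer no single-change step to work from.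

Next in line is compound 3 (`C=C(c1ccc(OC)cc1NC(=O)CN(C)C)c1ccc(OC)c2c1OC(C)(C)C=C2`). Its difference from compound 2 is dimethylamino in place of amino on a saturated chain carbon bound to a carbonyl carbon with the rest of the structure unchanged: dimethylamino in place of amino on a saturated chain carbon bound to a carbonyl carbon. Among the compounds with values here, no measured pair covers this change, so the expectation rests on compound 2 at 120 nM as its only anchor. In this assay the expected step of a 1.3-fold higher number from compound 2 to compound 3 (0.10 log units; within the scatter) is small, with a slight lean toward weaker inhibition, and it may well stay within the scatter. The estimated value for compound 3 is 150 nM within an expected range from 50 nM to 450 nM on this scale.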

Compound 3, half-maximal inhibitory concentration: 900 nM
For compound 3 the middle estimate is 6.0-fold (0.78 log units) below the measured one, outside the stated range (above it).
By their numbers in this assay, from the lowest: compounds 1 and 2 (each within the scatter of the next); then compound 3.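

In this assay, going by these compounds alone, dimethylamino in place of amino on a saturated chain carbon bound to a carbonyl carbon gives a 7.5-fold higher number from compound 2 to compound 3 (0.88 log units; beyond the scatter) as the first single-change step, and it shows that this place is sensitive to substitution, with the change leading to weaker inhibition. Across the change, heavy atoms go from 1 to 3 and hydrogen-bond donors from 1 to 0, with 1 hydrogen-bond acceptor on each side, and this single pair cannot separate the added carbons from the lost donor. No measurement is at hand that bears on the origin of the step.

The compounds shown leave open how methylamino, or a cyclic amine such as pyrrolidinyl, would read at this place, and so whether the weakening follows the loss of the donor or the number of added carbons. As far as these compounds go, it also remains open whether the same change would give a step of similar size on the core of compound 1, which carries a carbonyl and a hydroxy group where compound 2 has other groups.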